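The source may hold more compounds than are shown below. What is called first, only, known or untested is meant among the compounds shown, and "the series" means these compounds.

In a functional assay on DU-145 cells (Homo sapiens) for inhibition, read by trypan blue exclusion, with a stated time of 96 h (on this read-out higher numbers stand for weaker inhibition of growth and lower numbers for stronger inhibition of growth), compound 3 (`Cc1ccc(C)c(/C=C(\C(=O)c2ccc(Br)cc2)S(=O)(=O)Cc2ccc(F)cc2)c1`) gives the lowest of the three measured numbers at 1000 nM, compared with compound 2 (`Cc1cc(C)cc(/C=C(\C(=O)c2ccc(Br)cc2)S(=O)(=O)Cc2ccc(F)cc2)c1`) at 10000 nM and compound 1 (`COc1ccc(/C=C(\C(=O)c2ccc(Br)cc2)S(=O)(=O)Cc2ccc(Cl)cc2)cc1`) at 25000 nM. Compound 4 (`COc1ccc(/C=C(\C(=O)c2ccc(Br)cc2)S(=O)(=O)Cc2ccc(F)cc2)cc1`) has 4-methoxyphenyl in place of 2,5-dimethylphenyl on a double-bonded chain carbon bound to a double-bonded chain carbon. Within the data shown here, the only measured step at this place is a 10-fold lower number from compound 2 to compound 3 (1.00 log units; beyond the scatter), which is beyond the scatter. Compound 1 also carries 4-methoxyphenyl and gives 25000 nM, though it is not otherwise identical to compound 4. A higher number of similar size is therefore expected in this assay. The expected change is a 10-fold higher number from compound 3 to compound 4 (1.00 log units; beyond the scatter). For compound 4 the estimated value is 10000 nM, with an expected range of 3000 nM to 30000 nM.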

Compound 4, concentration for 50% growth inhibition: 25000 nM
Compound 4: the middle estimate sits 2.5-fold (0.40 log units) below what was measured; low and high end bracket the measured number.
By their numbers in this assay, from the lowest: compound 3; then compound 2; then compounds 1 and 4 (each within the scatter of the next).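

In this assay the group on the double-bonded chain carbon sets the number more widely than the earlier pair showed: 4-methoxyphenyl gives a 25-fold higher number from compound 3 to compound 4 (1.40 log units; beyond the scatter) and a 2.5-fold higher number from compound 2 to compound 4 (0.40 log units; beyond the scatter) and leaves 2,5-dimethylphenyl as the best of the three groups compared here. Fluoro in place of chloro on an aromatic carbon gives no change at the digits printed from compound 1 to compound 4 (within the scatter) with 4-methoxyphenyl present. No measurement here accounts for these steps.

On these data alone, whether a 2,5-dimethoxyphenyl group or an aminophenyl group at this place would match compound 3 stays open. So does whether chloro would match fluoro alongside 2,5-dimethylphenyl.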